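This account rests on a few compounds, and the source may have more. Where it says the series, first, only, none or still open, it means among the compounds named here.

Compound 1 `CCCc1nc(C(F)(F)F)ccc1CNC(=O)C(C)c1ccc(NS(C)(=O)=O)c(F)c1` — in an assay on CHO cells for antagonist activity at transient receptor potential cation channel subfamily V member 1 (Homo sapiens), read by FLIPR and calcium flux (on this read-out higher numbers stand for weaker inhibition and lower numbers for stronger inhibition), compound 1 gives 22.7 nM
Compound 2 `CCC1CC=C(c2nc(C(F)(F)F)ccc2CNC(=O)C(C)c2ccc(NS(C)(=O)=O)c(F)c2)CC1` — in this assay compound 2 gives 0.1 nM

Compound 2 holds the lower of the two numbers, separated from compound 1 by a 230-fold lower number from compound 1 to compound 2 (2.36 log units; beyond the scatter). Compound 3 `CC(C(=O)NCc1ccc(C(F)(F)F)nc1C1=CCC(C(C)(C)C)CC1)c1ccc(NS(C)(=O)=O)c(F)c1` carries tert-butyl in place of ethyl on a saturated ring carbon, tert-butyl in place of ethyl on a saturated ring carbon. Among the measured compounds shown here, no measured pair covers this change: the single step from compound 1 to compound 2 concerns the group on the aromatic carbon, not a substituent on the six-membered non-aromatic ring. For the measured compounds named here, with no bearing step, compound 3 is expected to stay within the scatter of compound 2, an estimated 1.5-fold higher number from compound 2 to compound 3 (0.18 log units; within the scatter). Compound 3 is therefore estimated at 0.15 nM, between 0.04 nM and 0.6 nM.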

Compound 3, inhibition constant: 0.2 nM
The estimate for compound 3 lay 1.3-fold (0.12 log units) below the measured number, and the stated range covers the measured number.
By their numbers in this assay, from the lowest: compounds 2 and 3 (each within the scatter of the next); then compound 1.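

In this assay, the saturated ring carbon takes tert-butyl in place of ethyl with no change beyond the scatter (a 2.0-fold higher number from compound 2 to compound 3 (0.30 log units; within the scatter)). The large separation from the propyl compound also holds with the bulkier ring group (a 110-fold lower number from compound 1 to compound 3 (2.05 log units; beyond the scatter)), so it is not confined to 4-ethylcyclohex-1-en-1-yl. No supporting data offer an explanation for this tolerance.

From the compounds shown here alone, whether an amine or a carboxylic acid at this ring carbon would be tolerated remains open. So does the outcome for a fully saturated cyclohexyl ring.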